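This account rests on a few compounds, and the source may have more. Where it says the series, first, only, none or still open, it means among the compounds named here.

Compound 1 `O=C1C(=O)N(CN2CCN(c3ccnc4cc(C(F)(F)F)ccc34)CC2)c2cc(Cl)ccc21` and compound 2 `O=C1C(=O)N(CN2CCN(c3ccnc4cc(C(F)(F)F)ccc34)CC2)c2cc(Br)ccc21` share one core and differ only in bromo in place of chloro on an aromatic carbon. In an ADME assay on MCF-10A cells (Homo sapiens) for cytotoxicity, read by sulforhodamine B assay, with a stated time of 48 h (a lower number here means a stronger inhibitor of growth, a higher number a weaker inhibitor of growth), compound 1 gives 32800 nM, and compound 2 gives 24500 nM, so the step of a 1.3-fold lower number from compound 1 to compound 2 (0.13 log units; within the scatter). Compound 3 `NC(=S)N/N=C1/C(=O)N(CN2CCN(c3ccnc4cc(C(F)(F)F)ccc34)CC2)c2cc(Cl)ccc21` carries a second core, with a thiosemicarbazone in place of one carbonyl; the difference between the two cores is not broken down here. In this assay compound 3 gives 38800 nM. Compound 4 `NC(=S)N/N=C1/C(=O)N(CN2CCN(c3ccnc4cc(C(F)(F)F)ccc34)CC2)c2cc(Br)ccc21` is built from compound 3 by the same change, (bromo in place of chloro on an aromatic carbon), at the same place. A step of similar size is expected, a 1.3-fold lower number from compound 3 to compound 4 (0.11 log units; within the scatter), because the earlier change gave a 1.3-fold lower number from compound 1 to compound 2 (0.13 log units; within the scatter). Compound 4 is therefore expected at about 30000 nM, estimated to fall between 15000 nM and 60000 nM.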

Compound 4, concentration for 50% growth inhibition: 27000 nM
Beside the measured number, compound 4's estimate is 1.1-fold (0.05 log units) above it; the range from low to high includes it.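

In this assay putting bromo in place of chloro on an aromatic carbon gives a 1.4-fold lower number from compound 3 to compound 4 (0.16 log units; within the scatter) and this step agrees with the one on the other core: the same change on two cores in this assay, a 1.3-fold lower number (0.13 log units; within the scatter) from compound 1 to compound 2 and a 1.4-fold lower number (0.16 log units; within the scatter) from compound 3 to compound 4, 1.1-fold (0.03 log units) apart, within the scatter of two such steps. The change therefore carried from one core to the other in this pair of cores with no measurable difference in step size. Yet each step lies within the scatter, so the data do not show that bromo and chloro truly differ here, and two cores say nothing about a third.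

The compounds shown leave open what other groups at this place would do, such as an amine, a carboxylic acid or a methoxy group. They also leave open whether a step beyond the scatter would carry between these cores equally well.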